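Swapping methoxy for methylamino on a longer side chain

The source may hold more compounds than are shown below. What is called first, only, known or untested is meant among the compounds shown, and "the series" means these compounds.

In a functional assay on SW480 cells (Homo sapiens) for antiproliferative activity, read by MTT assay, with a stated time of 48 h (a higher number here means a weaker inhibitor, a lower number a stronger inhibitor), compound 1 `CCCCCCCC(CCO)n1cnc2c(OC)ncnc21` gives 23900 nM, and compound 2 `CCCCCCCC(CCO)n1cnc2c(NC)ncnc21` gives 15300 nM. The change between them is methylamino in place of methoxy on an aromatic carbon and it made a 1.6-fold lower number from compound 1 to compound 2 (0.19 log units; within the scatter). Compound 3 `CCCCCCCCC(CCO)n1cnc2c(OC)ncnc21` differs from compound 1 by methyl in place of hydrogen on a saturated chain carbon, eight bonds along the chain from an aromatic nitrogen, and in this assay compound 3 gives 24600 nM, a step of a 1.0-fold higher number from compound 1 to compound 3 (0.01 log units; within the scatter). Compound 4 `CCCCCCCCC(CCO)n1cnc2c(NC)ncnc21` has not yet been measured. It differs from compound 3 by methylamino in place of methoxy on an aromatic carbon, the same change as that made from compound 1 to compound 2, at the same place. Because a 1.0-fold higher number from compound 1 to compound 3 (0.01 log units; within the scatter) stayed within the scatter and a 1.6-fold lower number from compound 1 to compound 2 (0.19 log units; within the scatter) did as well, the expected step is a 1.6-fold lower number from compound 3 to compound 4 (0.20 log units; within the scatter), close to the earlier one. Compound 4 is therefore estimated at 15500 nM in this assay, most likely between 8000 nM and 30000 nM.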

Compound 4, half-maximal inhibitory concentration: 3770 nM
The estimate for compound 4 lay 4.1-fold (0.61 log units) above the measured number, and the stated range ends above it.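

In this assay, methylamino in place of methoxy gave a 6.5-fold lower number from compound 3 to compound 4 (0.81 log units; beyond the scatter) on the longer chain, and this step does not match the one on the shorter chain: the same change on two cores in this assay, a 1.6-fold lower number (0.19 log units; within the scatter) from compound 1 to compound 2 and a 6.5-fold lower number (0.81 log units; beyond the scatter) from compound 3 to compound 4, 4.2-fold (0.62 log units) apart, beyond the scatter of two such steps. Seen the other way, adding the methyl to the chain gave a 4.1-fold lower number from compound 2 to compound 4 (0.61 log units; beyond the scatter) with methylamino present, and this step also differs from its counterpart with methoxy: the same change on two cores in this assay, a 1.0-fold higher number (0.01 log units; within the scatter) from compound 1 to compound 3 and a 4.1-fold lower number (0.61 log units; beyond the scatter) from compound 2 to compound 4, 4.2-fold (0.62 log units) apart, beyond the scatter of two such steps. The two changes therefore do not add up independently in these compounds, so a step seen on one core cannot simply be carried to another here, though these data do not show why.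

Still open, going by these compounds, is whether the larger step persists with a longer chain. Also open, on these data alone, is how an ethylamino or dimethylamino group would compare with methylamino on either chain.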